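The compounds below may be only part of what the source reports. "The series", "measured", "known", "first", "only" and "open" are said of these compounds alone.

Compound 1 `FC(F)(F)c1ccc(CSc2nc(N3CCCCC3)c3ccccc3n2)cc1` carries piperidin-1-yl on the shared core, and in a functional assay on MGC-803 cells (Homo sapiens) for cytotoxicity, read by MTT assay, with a stated time of 72 h (on this read-out lower numbers stand for stronger inhibition and higher numbers for weaker inhibition), compound 1 gives 18600 nM. Compound 2 `FC(F)(F)c1ccc(CSc2nc(Nc3ccccc3)c3ccccc3n2)cc1` has anilino in place of piperidin-1-yl on an aromatic carbon, and in this assay compound 2 gives 22200 nM; the step of a 1.2-fold higher number from compound 1 to compound 2 (0.08 log units; within the scatter). Compound 3 `FC(F)(F)c1ccc(CSc2nc(Nc3ccccc3Cl)c3ccccc3n2)cc1` has chloro in place of hydrogen on an aromatic carbon of that anilino. In this assay compound 3 reaches only a limit, > 50000 nM, so its true number is not known. The steps of an at least 2.6-fold higher number from compound 1 to compound 3 (0.42 log units; beyond the scatter) and an at least 2.2-fold higher number from compound 2 to compound 3 (0.35 log units; beyond the scatter) therefore rest on (the limit of > 50000 nM in this assay, at which 1 of the 3 values shown sits).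

Compound 4 `CCOc1ccccc1Nc1nc(SCc2ccc(C(F)(F)F)cc2)nc2ccccc12` differs from compound 3 in one place: ethoxy in place of chloro on an aromatic carbon. Going by the values given here, no measured step exchanges one group for another ortho to a large group, so the closest guide is the step from compound 2 to compound 3, where placing chloro there pushed the number past the limit. An ethoxy group there is expected to give compound 4 a number near that of compound 3, with the estimated step of an at least 1.2-fold lower number from compound 3 to compound 4 (0.09 log units; that floor lies within the scatter) not clearly beyond the scatter. Compound 4 is thus expected at about 40000 nM, within 12000 nM to 120000 nM.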

Compound 4, half-maximal inhibitory concentration: > 50000 nM
Compound 4 was reported as a limit; the forecaster's own chance of this, stated with the estimate: 45%; at least 1.2-fold (0.09 log units) between middle value and limit.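

In this assay compound 4 gives > 50000 nM, which is a limit and not a number. Chloro is therefore not the only group that goes with a weaker result at this place, ortho to a large group: ethoxy gives an at least 2.2-fold higher number from compound 2 to compound 4 (0.35 log units; beyond the scatter), and measured against the piperidin-1-yl compound it gives an at least 2.6-fold higher number from compound 1 to compound 4 (0.42 log units; beyond the scatter). The step between the two limits cannot be read, so chloro and ethoxy cannot be ranked against each other, and the comparison stops at this point: the limit of > 50000 nM in this assay, at which 2 of the 4 values shown sit.

On these data alone, it remains open whether a group such as fluoro, methyl or an amine at this same place would keep the result close to that of compound 2. Also open, as far as these compounds go, is whether chloro or ethoxy on another carbon of that ring would behave the same way.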